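Small Steps at the Carbonyl: Compound 3 to Compound 4

A few compounds are considered here, and "the series" means these few. Any claim that something is new, unique, unknown or untested is made for them only; others in the source may bear on it.

- compound 1 `Cc1ccc(C(=O)Nc2cc(Cl)ccc2OCC(=O)Nc2ccc(S(N)(=O)=O)cc2C)cc1` gives 54200 nM
- compound 2 `Cc1cc(S(N)(=O)=O)ccc1NC(=O)COc1ccc(Cl)cc1NC(=O)c1cccc(Cl)c1` gives 59700 nM
- compound 3 `COc1ccc(C(=O)Nc2cc(Cl)ccc2OCC(=O)Nc2ccc(S(N)(=O)=O)cc2C)cc1` gives 69500 nM

These values come from a functional assay on C8166 cells (Homo sapiens) for cytotoxicity, read by MTT assay; on this read-out lower numbers stand for higher toxicity in this test and higher numbers for lower toxicity in this test. Compound 3 stands within the scatter of both other compounds, with a 1.2-fold higher number from compound 2 to compound 3 (0.07 log units; within the scatter) and a 1.3-fold higher number from compound 1 to compound 3 (0.11 log units; within the scatter). Compound 4 `Cc1cc(S(N)(=O)=O)ccc1NC(=O)COc1ccc(Cl)cc1NC(=O)c1cc(Cl)ccc1Cl` remains unmeasured, and it differs from compound 3 as follows: 2,5-dichlorophenyl in place of 4-methoxyphenyl on a carbonyl carbon. For the measured compounds named here, two of the measured steps also exchange the group on a carbonyl carbon, the one above from compound 2 and a 1.1-fold higher number from compound 1 to compound 2 (0.04 log units; within the scatter). Both are small. Going by the values given here, no measured compound carries 2,5-dichlorophenyl, so this evidence is indirect, and no step beyond the scatter is expected. The expected step is a 1.2-fold lower number from compound 3 to compound 4 (0.08 log units; within the scatter). For compound 4 the estimated value is 58000 nM, within an expected range of 32000 nM to 100000 nM.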

Compound 4, half-maximal cytotoxic concentration: 42100 nM
Beside the measured number, compound 4's estimate is 1.4-fold (0.14 log units) above it; measured number inside the range.
By their numbers in this assay, from the lowest: compounds 4, 1, 2 and 3 (each within the scatter of the next).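

In this assay the change to 2,5-dichlorophenyl on a carbonyl carbon stays within the scatter whichever group leaves, 4-methoxyphenyl (a 1.7-fold lower number from compound 3 to compound 4 (0.22 log units; within the scatter)) or 4-methylphenyl (a 1.3-fold lower number from compound 1 to compound 4 (0.11 log units; within the scatter)), and so does chloro in place of hydrogen on an aromatic carbon (a 1.4-fold lower number from compound 2 to compound 4 (0.15 log units; within the scatter)). A ring with two chlorines at this position therefore adds no step beyond the scatter among these four compounds. Nothing measured here accounts for the size of these steps. Still open, going by these compounds, is whether an amine or a carboxylic acid on this ring, or cyclohexyl in place of the aromatic ring, would also stay within the scatter.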